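This account rests on a few compounds, and the source may have more. Where it says the series, first, only, none or still open, it means among the compounds named here.

Working notes on the hydrazide series.

Three analogues sharing one core have been measured in an assay on cells for agonist activity at ecdysone receptor (Bombyx mori), read by a luciferase reporter, with a stated time of 24 h; on this read-out higher numbers stand for an effect only at larger amounts of compound and lower numbers for an effect already at smaller amounts. Compound 1 `CC(C)(C)N(NC(=O)c1ccccc1Cl)C(=O)c1ccccc1Cl` gives 331 nM. Compound 2 `CC(C)(C)N(NC(=O)c1cccc(F)c1)C(=O)c1ccccc1Cl` gives 69.2 nM, and compound 3 `CC(C)(C)N(NC(=O)c1ccc(Br)cc1)C(=O)c1ccccc1Cl` gives 33.9 nM. Compound 3 thus holds the lowest number of the three: the steps are a 9.8-fold lower number from compound 1 to compound 3 (0.99 log units; beyond the scatter) and a 2.0-fold lower number from compound 2 to compound 3 (0.31 log units; beyond the scatter), with a 4.8-fold lower number from compound 1 to compound 2 (0.68 log units; beyond the scatter) completing the set, each beyond the scatter.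

The next analogue, compound 4 `CC(C)(C)N(NC(=O)c1cccc(Cl)c1Cl)C(=O)c1ccccc1Cl`, differs from compound 3 in one place: 2,3-dichlorophenyl in place of 4-bromophenyl on a carbonyl carbon. The 2,3-dichlorophenyl that enters resembles the 2-chlorophenyl of compound 1 more than the 4-bromophenyl that leaves, with one chlorine added. For the measured compounds named here, the step most relevant is therefore a 9.8-fold lower number from compound 1 to compound 3 (0.99 log units; beyond the scatter), read in reverse, since compound 4 moves the ring substitution back toward that of compound 1; the additional chlorine has no measured counterpart in the set, so its effect is unknown.

On that basis a higher number in this assay is expected for compound 4, short of a full return to compound 1, because 331 nM marks the measured end of that direction. The expected step is a 5.9-fold higher number from compound 3 to compound 4 (0.77 log units; beyond the scatter). For compound 4 the estimate is 200 nM, with a range from 60 nM to 700 nM.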

Compound 4, half-maximal effective concentration: 9.33 nM
The estimate for compound 4 lay 21-fold (1.33 log units) above the measured number; the whole stated range lies above it.
By their numbers in this assay, from the lowest: compound 4; then compound 3; then compound 2; then compound 1.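

On the carbonyl carbon whose other neighbours are an amide-type nitrogen, chloro in place of hydrogen on an aromatic carbon gives a 35-fold lower number from compound 1 to compound 4 (1.55 log units; beyond the scatter) in this assay, so the 2-chlorophenyl of compound 1 can be extended here to reach the lowest number in the set. The earlier compounds shown here left 2-chlorophenyl with the highest number and could be read as favouring its removal, but compound 4 goes against that reading: it retains that chlorine, and 2,3-dichlorophenyl also gives a 3.6-fold lower number from compound 3 to compound 4 (0.56 log units; beyond the scatter) and a 7.4-fold lower number from compound 2 to compound 4 (0.87 log units; beyond the scatter), so neither 4-bromophenyl nor 3-fluorophenyl marks the low end at this position. No measurement at hand accounts for this reversal.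

Whether the second chlorine needs the first remains open, as 3-chlorophenyl is not among the compounds shown, and neither is 2,3-dimethylphenyl, which would test whether chlorine itself matters at these ring positions. Going by these compounds, the 2-chlorophenyl on the other carbonyl is common to all four compounds, so whether the same order holds with a group such as 4-methoxyphenyl in its place also remains open.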